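Removing a methoxy from a sulfonamide that already tests weak

A few compounds are considered here, and "the series" means these few. Any claim that something is new, unique, unknown or untested is made for them only; others in the source may bear on it.

Of the compounds shown here, two from this series have been tested in a functional assay on HCT-116 cells (Homo sapiens) for inhibition, read by MTT assay, with a stated time of 72 h; a higher number here means a weaker inhibitor, a lower number a stronger inhibitor. Compound 1, `CCOC(=O)c1oc2ccc(NS(=O)(=O)c3ccc(Cl)cc3)cc2c1C`, gives a half-maximal inhibitory concentration of 24300 nM. Compound 2, `CCOC(=O)c1oc2ccc(N(Cc3ccccc3)S(=O)(=O)c3ccc(OC)cc3)cc2c1C`, carries a benzyl group on the sulfonamide nitrogen and a methoxy on the sulfonyl-bearing ring. In this assay compound 2 reaches only the limit of the assay, > 40000 nM, which is a boundary rather than a measured number, as the limit of > 40000 nM in this assay, at which 1 of the 2 values shown sits, shows. Compound 2 therefore stands at the weak end of what is shown, with no number of its own.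

The next compound, compound 3, `CCOC(=O)c1oc2ccc(N(Cc3ccccc3)S(=O)(=O)c3ccccc3)cc2c1C`, keeps the benzyl-bearing sulfonamide of compound 2 but changes one place: hydrogen in place of methoxy on an aromatic carbon. Within the data shown here, no measured pair shows what such a change does in this assay, so the step remains open. With compound 2 already at the limit, the step from compound 2 to compound 3 is expected to be small, a step that the limit leaves unreadable from compound 2 to compound 3, with no direction beyond the scatter. Compound 3 is estimated at 50000 nM, between 20000 nM and 150000 nM, and a limit is again the likely outcome.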

Compound 3, half-maximal inhibitory concentration: > 40000 nM
Compound 3 was reported as a limit; the forecaster's own chance of this, stated with the estimate: 65%; the middle value does not contradict the limit.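

Among these compounds, compound 2 and compound 3 both reach only a limit of the assay rather than a number, so no step between them can be read: the limit of > 40000 nM in this assay, at which 2 of the 3 values shown sit. What the compounds shown leave open is how hydrogen in place of methoxy acts in this assay on a compound that gives a measured number rather than a limit.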